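Removing a Fluoro Group from Compound 3

This account rests on a few compounds, and the source may have more. Where it says the series, first, only, none or still open, it means among the compounds named here.

Three related sulfonamides have been measured so far. In a functional assay on NCI/ADR-RES cells (Homo sapiens) for cytotoxicity (on this read-out higher numbers stand for weaker inhibition of growth and lower numbers for stronger inhibition of growth), compound 1 (`COc1ccc(NS(=O)(=O)c2cc(F)c(F)c(F)c2F)cc1`) gives 400 nM while compound 2 (`COc1ccc(NS(=O)(=O)c2c(F)c(F)c(F)c(Br)c2F)cc1`) gives 190 nM and compound 3 (`COc1ccc(NS(=O)(=O)c2c(F)cc(F)c(F)c2F)cc1`) gives 4500 nM as the highest of the three numbers. Both other compounds lie lower than compound 3 by more than the scatter.

Compound 4 (`COc1ccc(NS(=O)(=O)c2ccc(F)c(F)c2F)cc1`) follows from compound 3 through hydrogen in place of fluoro on an aromatic carbon with hydrogen in place of fluoro on an aromatic carbon. The nearest measured step is a 24-fold higher number from compound 2 to compound 3 (1.37 log units; beyond the scatter) and it is large. There, however, hydrogen replaces bromo rather than fluoro, so it suggests a direction more than a size. Compound 1 and compound 3 are isomers, and compound 1 at 400 nM stands well apart from compound 3 at 4500 nM in this pair. The arrangement of ring substituents alone can therefore move the number a long way, which argues for a wide range. A modest rise is expected in this assay for the new step, and it may not clear the scatter. The expected step is a 1.6-fold higher number from compound 3 to compound 4 (0.19 log units; within the scatter) and would remain within the scatter. Compound 4 is estimated at 7000 nM (expected range 1500 nM to 30000 nM).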

Compound 4, concentration for 50% growth inhibition: > 50000 nM
Compound 4: no number, only a limit (the forecaster's own chance of this, stated with the estimate: 15%); at least 7.1-fold (0.85 log units) between middle value and limit.
By their numbers in this assay, from the lowest: compound 2; then compound 1; then compound 3. At a limit, above all of these: compound 4.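

Compound 4 gives no number in this assay, only a limit: the limit of > 50000 nM in this assay, at which 1 of the 4 values shown sits.

Replacing a single fluoro with hydrogen on this carbon, ortho to a large group and para to a fluoro group, gives an at least 11-fold higher number from compound 3 to compound 4 (1.04 log units; beyond the scatter) and so shows that a change of one heavy atom at this position can be large, which the earlier bromo step, made at another place on the ring, could only hint at. Hydrogen in place of a fluoro on a different carbon of the ring gives an at least 120-fold higher number from compound 1 to compound 4 (2.09 log units; beyond the scatter) and so the large rise is not tied to this one position: among the compounds shown, neither of these two fluoro groups is lost without one.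

The limit leaves the true size of both steps open, and the compounds shown do not tell whether fluoro itself is needed on this carbon or whether any group other than hydrogen would serve. A chloro, a methyl or an amine on the same carbon would separate those two readings.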